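Working notes: 2,3-difluorophenyl in place of pyridin-3-yl

A few compounds are considered here, and "the series" means these few. Any claim that something is new, unique, unknown or untested is made for them only; others in the source may bear on it.

Compound 1 `CC(C)Cc1csc(N)c1C(=O)c1ccc(Cl)cc1`, compound 2 `CC(C)(C)Cc1c(-c2ccncc2)sc(N)c1C(=O)c1ccc(Cl)cc1` and compound 3 `CC(C)(C)Cc1c(-c2cccnc2)sc(N)c1C(=O)c1ccc(Cl)cc1` share one core and have all been run in an assay on CHO cells for displacement of a labelled ligand from adenosine receptor A1 (Homo sapiens), read by scintillation counting, tested at 10 uM; on this read-out lower numbers stand for less inhibition and higher numbers for more inhibition at the one concentration tested (going by the name of the read-out). Compound 1 gives 1%, compound 2 gives 1%, and compound 3 gives 1%. Among the compounds with values here, the only single-point step measured, no change at the digits printed from compound 2 to compound 3 (within the scatter), shows no movement. Compound 3 therefore stands level with both other compounds, all of them at the floor of the read-out.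

Compound 4 `CC(C)(C)Cc1c(-c2cccc(F)c2F)sc(N)c1C(=O)c1ccc(Cl)cc1` differs from compound 3 by 2,3-difluorophenyl in place of pyridin-3-yl on an aromatic carbon. Within the data shown here, no measured step covers this exchange; the one step at the same place, no change at the digits printed from compound 2 to compound 3 (within the scatter), was flat, and nothing measured so far has lifted this series off the floor. The expected step is a number 1 percentage points higher from compound 3 to compound 4 (within the scatter), nothing beyond the scatter. Compound 4 is estimated at 2%, with a range from -8% to 14%.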

Compound 4, a percentage reported as inhibition, at one concentration (the size of the read-out at that concentration, not a potency): 1%
Beside the measured number, compound 4's estimate is 1 percentage points above it, within the range that was stated.
By their numbers in this assay, from the lowest: compounds 1, 2, 3 and 4 (each within the scatter of the next).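

Within this assay, the change at the position next to the ring sulfur now goes beyond moving a ring nitrogen: 2,3-difluorophenyl, a ring of carbon only, gives no change at the digits printed from compound 3 to compound 4 (within the scatter) and likewise no change at the digits printed from compound 2 to compound 4 (within the scatter). Neither pyridine isomer differs from this ring at the digits printed, so losing the ring nitrogen and its hydrogen-bond acceptor, and adding two fluorines, leaves the read-out unmoved. Nothing at hand explains this flat result.

From the compounds shown here alone, whether an aliphatic amine or a carboxylic acid at this position would lift the read-out remains open. With these compounds level, any ranking among these rings also remains open.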